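A few compounds are considered here, and "the series" means these few. Any claim that something is new, unique, unknown or untested is made for them only; others in the source may bear on it.

In a functional assay on HCT-116 cells (Homo sapiens) for antiproliferative activity, read by MTT assay, with a stated time of 72 h (a higher number here means a weaker inhibitor, a lower number a stronger inhibitor), the measured compounds stand as follows:

compound 1 `COc1ccc(N2C(=O)COc3ccc(-c4cnc(OC)c(NS(=O)(=O)c5ccc(F)cc5)c4)cc32)cc1` gives 13400 nM;
compound 2 `COc1ncc(-c2ccc3c(c2)N(C2CCCCC2)C(=O)CO3)cc1NS(=O)(=O)c1ccc(F)cc1` gives only a limit, > 40000 nM.

Compound 2 thus sits at the assay ceiling (the limit of > 40000 nM in this assay, at which 1 of the 2 values shown sits), with no number of its own. Compound 3 `COc1ncc(-c2ccc3c(c2)N(C(C)C)C(=O)CO3)cc1NS(=O)(=O)c1ccc(F)cc1` differs from it by isopropyl in place of cyclohexyl on an amide-type nitrogen in a ring. Within the data shown here, the only measured step, an at least 2.9-fold higher number from compound 1 to compound 2 (0.47 log units; beyond the scatter), weakened this assay when cyclohexyl entered; no step between two alkyl groups on this nitrogen exists. Compound 3 is therefore expected to show a number no higher from compound 2 to compound 3 (the limit leaves the size open), essentially no shift beyond the scatter. Compound 3 is estimated at 40000 nM, within 12000 nM to 120000 nM.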

Compound 3, half-maximal inhibitory concentration: 19200 nM
For compound 3 the middle estimate is 2.1-fold (0.32 log units) above the measured one; low and high end bracket the measured number.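

On the amide-type nitrogen in a ring, the choice of alkyl group does register in this assay: isopropyl in place of cyclohexyl gives an at least 2.0-fold lower number from compound 2 to compound 3 (0.31 log units; beyond the scatter). The loss seen on leaving 4-methoxyphenyl therefore does not hold for every alkyl group, since isopropyl in its place gives a 1.4-fold higher number from compound 1 to compound 3 (0.16 log units; within the scatter). Compound 2 has only a limit, not a number: the limit of > 40000 nM in this assay, at which 1 of the 3 values shown sits.

Still open, going by these compounds, is how a methyl group, or a longer chain ending in an amine, on this nitrogen would read in this assay.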